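A Methyl on the Methoxymethyl Arm of Compound 3

A few compounds are considered here, and "the series" means these few. Any claim that something is new, unique, unknown or untested is made for them only; others in the source may bear on it.

Compound 1, `Cc1cc(-c2noc([C@H](C)NC(=O)c3cc(C(F)(F)F)nn3C)n2)ncn1`, gives 1410 nM in an assay on T-REx-293 cells for inhibition of potassium channel subfamily T member 1 (Homo sapiens), read by patch clamp; on this read-out higher numbers stand for weaker inhibition and lower numbers for stronger inhibition.
Compound 2, `C[C@H](NC(=O)c1cc(C(F)(F)F)nn1C)c1nc(-c2ccnc(N3CCCC3)c2)no1`, gives 573 nM in this assay.
Compound 3, `COCc1cc(-c2noc([C@H](C)NC(=O)c3cc(C(F)(F)F)nn3C)n2)ccn1`, gives 322 nM in this assay.

Compound 3 carries the lowest of the three numbers. The step of a 4.4-fold lower number from compound 1 to compound 3 (0.64 log units; beyond the scatter) lies beyond the scatter, whereas the step of a 1.8-fold lower number from compound 2 to compound 3 (0.25 log units; within the scatter) stays within it, so compound 3 and compound 2 cannot be told apart on these numbers.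

Compound 4, `CO[C@@H](C)c1cc(-c2noc([C@H](C)NC(=O)c3cc(C(F)(F)F)nn3C)n2)ccn1`, differs from compound 3 by methyl in place of hydrogen on a saturated chain carbon bound to an aromatic carbon and an oxygen on a saturated carbon. Neither measured step bears directly on this: the step from compound 1 to compound 3 exchanges one aromatic ring for another, and the step from compound 2 to compound 3 exchanges a pyrrolidin-1-yl for a methoxymethyl. For the measured compounds named here, no step in the set adds a single methyl to a saturated chain carbon. With nothing to point either way, compound 4 is expected to stay close to compound 3, a step of a 1.0-fold lower number from compound 3 to compound 4 (0.00 log units; within the scatter) that is estimated to fall within the scatter. Compound 4 is therefore estimated at 320 nM, in the range 110 nM to 950 nM.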

Compound 4, half-maximal inhibitory concentration: 744 nM
Compound 4: the middle estimate sits 2.3-fold (0.37 log units) below what was measured; measured number inside the range.
By their numbers in this assay, from the lowest: compounds 3, 2, 4 and 1 (each within the scatter of the next, the first and the last beyond it).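

On the saturated chain carbon bound to an aromatic carbon and an oxygen, the smallest change in the set is not silent in this assay: methyl in place of hydrogen gives a 2.3-fold higher number from compound 3 to compound 4 (0.36 log units; beyond the scatter) and so weakens inhibition. The edge of the methoxymethyl arm over the ring of compound 1 is also not kept by 1-methoxyethyl, since a 1.9-fold lower number from compound 1 to compound 4 (0.28 log units; within the scatter) stays within the scatter, and 1-methoxyethyl cannot be told apart from pyrrolidin-1-yl either, with a 1.3-fold higher number from compound 2 to compound 4 (0.11 log units; within the scatter) also within it. Nothing measured here explains why this methyl costs inhibition.

The compounds shown leave open whether the other spatial arrangement at this chain carbon would read the same way. They also leave open what an ethyl, a hydroxyl or a second methyl on that carbon would do.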